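Thiazolylthioethyl replacing prenyl on the azine nitrogen

The source may hold more compounds than are shown below. What is called first, only, known or untested is meant among the compounds shown, and "the series" means these compounds.

Measured compounds:
compound 1 `Oc1nnc(-c2cccnc2)c2ccccc12`: 26%
compound 2 `CC(C)=CCn1nc(-c2cccnc2)c2ccccc2c1=O`: 94%
compound 3 `O=c1c2ccccc2c(-c2cccnc2)nn1S(=O)(=O)c1ccccc1`: 96%

Of the compounds shown here, three sharing one core have been measured in an assay on isolated protein (Oryctolagus cuniculus) with Thromboxane-A synthase (Homo sapiens) as the target, tested at 1 uM; a higher number here means more inhibition at the concentration tested (going by the name of the read-out), a lower number less inhibition. Compound 1 `Oc1nnc(-c2cccnc2)c2ccccc12` gives 26%, the lowest of the three. Compound 2 `CC(C)=CCn1nc(-c2cccnc2)c2ccccc2c1=O` gives 94% in this assay, the second highest number of the three. Its nearest neighbour is compound 3 `O=c1c2ccccc2c(-c2cccnc2)nn1S(=O)(=O)c1ccccc1`, which gives 96% in this assay; these two values lie within the scatter of each other. The gap between compound 2 and compound 1 is far beyond the scatter.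

Compound 4 `O=c1c2ccccc2c(-c2cccnc2)nn1CCSc1nccs1` has not yet been measured in this assay. It differs from compound 2 in one place: ((1,3-thiazol-2-yl)sulfanyl)methyl in place of 2-methylprop-1-en-1-yl on a saturated chain carbon bound to an aromatic nitrogen. For the measured compounds named here, no measured pair records this particular change, so its effect has to be inferred from what compound 2 and compound 3 show, namely that two quite different groups on the aromatic nitrogen both sit at high inhibition.

On that basis the expected step of a number 6 percentage points lower from compound 2 to compound 4 (within the scatter) is small, within the scatter, leaning slightly downward. Compound 4 is therefore estimated at 88%, within a range of 72% to 98%.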

Compound 4, a percentage reported as inhibition, at one concentration (the size of the read-out at that concentration, not a potency): 97%
Compound 4: middle estimate off by 9 percentage points, on the low side, and the stated range covers the measured number.
By their numbers in this assay, from the lowest: compound 1; then compounds 2, 3 and 4 (each within the scatter of the next).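

In this assay, the step at this saturated chain carbon bound to an aromatic nitrogen is a number 3 percentage points higher from compound 2 to compound 4 (within the scatter), so the exchange of 2-methylprop-1-en-1-yl for ((1,3-thiazol-2-yl)sulfanyl)methyl does not separate the two compounds. For the compounds shown here, this is the first direct reading at this place, and it shows that a group with a five-membered aromatic ring and hydrogen-bond acceptors is carried as well as an open chain with neither, even with the double bond gone. No supporting measurement is available to explain why such different groups give numbers this close.

Still open, as far as these compounds go, is what happens when an amine such as dimethylamino, a carboxylic acid or a longer chain bearing the same thiazolylsulfanyl group stands in place of ((1,3-thiazol-2-yl)sulfanyl)methyl. Since this assay gives the size of inhibition at one concentration and not a potency, and compound 2 and compound 4 both lie high on it, any difference in potency between them also remains unresolved.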